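Two bicyclic adenosine derivatives and a single unmeasured analogue

The source may hold more compounds than are shown below. What is called first, only, known or untested is meant among the compounds shown, and "the series" means these compounds.

The compounds here were tested in a functional assay for antagonist activity at adenosine receptor A3 (Homo sapiens), with a stated time of 30 min; on this read-out higher numbers stand for weaker inhibition and lower numbers for stronger inhibition. Compound 1, whose structure is `CNC(=O)[C@@]12CO[C@@H]([C@H](n3cnc4c(N)ncnc43)O1)[C@@H]2O`, reaches only the limit of the assay in this assay, giving > 100000 nM. Compound 2, `CNC(=O)[C@@]12CO[C@@H]([C@H](n3cnc4c(NCc5cccc(I)c5)ncnc43)O1)[C@@H]2O`, carries 3-iodobenzyl in place of hydrogen on a nitrogen on an aromatic ring, the change described as 3-iodobenzyl in place of hydrogen on a nitrogen on an aromatic ring; in this assay compound 2 likewise reaches only a limit, with > 100000 nM. The step that the two limits leave unreadable from compound 1 to compound 2 therefore cannot be read, since both ends are limits.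

Compound 3, `Nc1ncnc2c1ncn2[C@@H]1O[C@@]2(CO)CN[C@@H]1[C@@H]2O`, has a different core; the difference between the two cores is not broken down here. In this assay compound 3 also sits at a limit, giving > 100000 nM. Going by the values given here, all three measured values share one feature, namely (the limit of > 100000 nM in this assay, at which 3 of the 3 values shown sit), so none of the measured compounds shows readable inhibition.

Compound 4, `OC[C@@]12CN[C@@H]([C@H](n3cnc4c(NCc5cccc(I)c5)ncnc43)O1)[C@@H]2O`, is not yet measured. It differs from compound 3 by 3-iodobenzyl in place of hydrogen on a nitrogen on an aromatic ring, the same change as that from compound 1 to compound 2, made on the same kind of place. Among the compounds with values here, since the one comparable step, from compound 1 to compound 2, gave no readable size, the expectation for compound 4 rests on the three limits alone. The expected step is a number no higher from compound 3 to compound 4 (the limit leaves the size open), which is to say no readable gain. Compound 4 is estimated to give about 100000 nM, most likely again as a limit, with a plausible range from 10000 nM to 300000 nM.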

Compound 4, half-maximal inhibitory concentration: 8.2 nM
Estimate against measurement, compound 4: 12000-fold (4.09 log units) above; the whole stated range lies above it.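

In this assay, replacing hydrogen with 3-iodobenzyl on a nitrogen on an aromatic ring gives an at least 12000-fold lower number from compound 3 to compound 4 (4.08 log units; beyond the scatter), so on the core of compound 3 this single change turns a compound with no readable inhibition into a strong inhibitor. On the core of compound 1 the same change leaves no readable inhibition: compound 2 gives > 100000 nM, which is a limit, and the step leading to it cannot be read. The effect of the change therefore does not carry automatically from one core to the other, but these two pairs do not show which part of the core decides the outcome, and they give no exact size for the gain, as the starting point is only a limit: the limit of > 100000 nM in this assay, at which 3 of the 4 values shown sit.

From the compounds shown here alone, it remains open whether the gain on the core of compound 3 needs the iodine, or whether plain benzyl or a longer alkyl chain on the same nitrogen would also give it. Going by these compounds, it is also open how much the hydroxymethyl group of compound 4 contributes, which a carboxylic acid or a methyl amide in its place could test.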